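A few compounds are considered here, and "the series" means these few. Any claim that something is new, unique, unknown or untested is made for them only; others in the source may bear on it.

Measured in a functional assay on K562 cells (Homo sapiens) for cytotoxicity, read by ELISA, with a stated time of 4 days; a higher number here means a weaker inhibitor, a lower number a stronger inhibitor:
compound 1 `Cc1ccsc1-c1cc(-c2ccoc2)cc(-c2ccc(Cl)cc2)n1` gives 19600 nM
compound 2 `Clc1ccc(-c2cc(-c3ccoc3)cc(-c3ccc(Cl)s3)n2)cc1` gives 19600 nM
compound 3 `Cc1ccsc1-c1cc(-c2ccc(Cl)o2)cc(-c2ccco2)n1` gives 10600 nM

Among the compounds with values here, the one change tried so far is 5-chlorothiophen-2-yl in place of 3-methylthiophen-2-yl on an aromatic carbon; its effect was no change at the digits printed from compound 1 to compound 2 (within the scatter). Compound 3 shares no counted single difference with compound 1; the difference between the two cores is not broken down here, and the values of compound 3 and compound 1 lie within the scatter of each other.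

Compound 4 `Clc1ccc(-c2cc(-c3ccco3)nc(-c3ccc(Cl)s3)c2)o1` has not yet been measured. It is reached from compound 3 by 5-chlorothiophen-2-yl in place of 3-methylthiophen-2-yl on an aromatic carbon. This is the same kind of change as that from compound 1 to compound 2, not the same: around the place, compound 3 carries a 5-chlorofuran-2-yl group and a furan-2-yl group where compound 1 carries a 4-chlorophenyl group and a furan-3-yl group.

The expectation for compound 4 in this assay rests on the flat step seen in no change at the digits printed from compound 1 to compound 2 (within the scatter): the expected step is a 1.0-fold higher number from compound 3 to compound 4 (0.02 log units; within the scatter). Compound 4 is therefore estimated at 11000 nM, within 5000 nM to 25000 nM.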

Compound 4, half-maximal inhibitory concentration: 22500 nM
Compound 4: middle estimate off by 2.0-fold (0.31 log units), on the low side; the range from low to high includes it.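

In this assay, 5-chlorothiophen-2-yl in place of 3-methylthiophen-2-yl on the core of compound 3 gives a 2.1-fold higher number from compound 3 to compound 4 (0.33 log units; beyond the scatter) in the number, and the same change on the core of compound 1 gave no change at the digits printed from compound 1 to compound 2 (within the scatter) in the number. Set side by side, the two steps do not separate from each other: the same change on two cores in this assay, no change at the digits printed (within the scatter) from compound 1 to compound 2 and a 2.1-fold higher number (0.33 log units; beyond the scatter) from compound 3 to compound 4, 2.1-fold (0.33 log units) apart, within the scatter of two such steps. Within the data shown here, the change can therefore be carried between these two cores with no gap between the steps that stands out of the scatter, but two pairs do not prove that the step is the same on both cores, and they say nothing about any other core.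

Still open, on these data alone, is how the same change behaves on a core that carries an amine or a carboxylic acid in place of the 5-chlorofuran-2-yl group. Also open, as far as these compounds go, is whether an alkyl amine or a longer chain on the aromatic carbon next to the ring nitrogen, in place of either thiophene, would move the number at all.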